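The source may report more compounds than this note shows. Statements on the series, on what has been measured and on what is new or still open speak of the compounds shown alone.

Measured compounds:
compound 1, `COc1cc(F)c(NC(=O)c2ccnc(Cl)c2)cc1Nc1nccc(-c2cn(C)c3ccccc23)n1`: 6890 nM
compound 2, `COc1cc(F)c(NC(=O)c2ccnc(O)c2)cc1Nc1nccc(-c2cn(C)c3ccccc23)n1`: 11700 nM
compound 3, `COc1cc(F)c(NC(=O)c2ccccn2)cc1Nc1nccc(-c2cn(C)c3ccccc23)n1`: 7980 nM

All three were tested in a functional assay on A549 cells (Homo sapiens) for antiproliferative activity, read by MTT assay, with a stated time of 72 h; on this read-out lower numbers stand for stronger inhibition and higher numbers for weaker inhibition. Compound 2 has the highest number of the three, but the gaps are small: a 1.7-fold higher number from compound 1 to compound 2 (0.23 log units; within the scatter), and a 1.5-fold lower number from compound 2 to compound 3 (0.17 log units; within the scatter). Compound 4, `COc1cc(F)c(NC(=O)c2cnccn2)cc1Nc1nccc(-c2cn(C)c3ccccc23)n1`, has not yet been measured in this assay. It differs from compound 2 in one place: pyrazin-2-yl in place of 2-hydroxypyridin-4-yl on a carbonyl carbon. Going by the values given here, the step that bears most directly on this change is the one from compound 2 to compound 3, where a different six-membered aromatic ring also replaced the 2-hydroxypyridin-4-yl group on the carbonyl carbon, and the result stayed within the scatter. A related ring swap, a 1.2-fold higher number from compound 1 to compound 3 (0.06 log units; within the scatter), was likewise within the scatter. Every change tried so far at this position has left the number essentially unchanged, so the expectation for compound 4 is no step beyond the scatter, with a slight lean to a lower number in line with compound 3. The expected change is a 1.4-fold lower number from compound 2 to compound 4 (0.14 log units; within the scatter). Compound 4 is therefore estimated at 8500 nM, with a range from 4000 nM to 18000 nM.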

Compound 4, half-maximal inhibitory concentration: 2490 nM
Estimate against measurement, compound 4: 3.4-fold (0.53 log units) above; measured number below the stated range.
By their numbers in this assay, from the lowest: compound 4; then compounds 1, 3 and 2 (each within the scatter of the next).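

Until now, no ring swap on this carbonyl carbon had moved the number beyond the scatter in this assay, so the position looked indifferent to the choice of ring. Pyrazin-2-yl is the first group to stand apart, with a 4.7-fold lower number from compound 2 to compound 4 (0.67 log units; beyond the scatter) and a 2.8-fold lower number from compound 1 to compound 4 (0.44 log units; beyond the scatter) and, most tellingly, a 3.2-fold lower number from compound 3 to compound 4 (0.51 log units; beyond the scatter) where the rings differ only by a ring nitrogen in place of a ring carbon. The position therefore does respond to the identity of the ring, although all three steps are modest in size.

On these data alone, whether a pyrimidin-2-yl ring, or a pyrazine ring carrying an amine or a methyl group, would lower the number further remains open. Nothing measured here explains why the pyrazin-2-yl ring gives the lower number.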